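Dimethoxyphenyl for Dimethylphenyl on the Trimethoxyphenyl Core

The compounds below may be only part of what the source reports. "The series", "measured", "known", "first", "only" and "open" are said of these compounds alone.

Three compounds have been measured in a functional assay on A549 cells (Homo sapiens) for antiproliferative activity, read by MTT assay, with a stated time of 24 h; on this read-out lower numbers stand for stronger inhibition and higher numbers for weaker inhibition:

Compound 1 `COc1ccc(-c2cc(/C=C/C(=O)c3ccc(C)c(C)c3)nc3cc(-c4ccccc4)nn23)cc1OC`: 9300 nM
Compound 2 `COc1ccc(C(=O)/C=C/c2cc(-c3ccc(OC)c(OC)c3)n3nc(-c4ccccc4)cc3n2)cc1OC`: 3900 nM
Compound 3 `COc1cc(-c2cc(/C=C/C(=O)c3ccc(C)c(C)c3)nc3cc(-c4ccccc4)nn23)cc(OC)c1OC`: 10600 nM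

Compound 2 differs from compound 1 by 3,4-dimethoxyphenyl in place of 3,4-dimethylphenyl on a carbonyl carbon, and this change gave a 2.4-fold lower number from compound 1 to compound 2 (0.38 log units; beyond the scatter). The core of compound 3 differs from that of compound 1 by methoxy in place of hydrogen on an aromatic carbon, a step of a 1.1-fold higher number from compound 1 to compound 3 (0.06 log units; within the scatter), so the two cores behave much alike here. Compound 4 `COc1ccc(C(=O)/C=C/c2cc(-c3cc(OC)c(OC)c(OC)c3)n3nc(-c4ccccc4)cc3n2)cc1OC` carries the same change relative to compound 3, namely (3,4-dimethoxyphenyl in place of 3,4-dimethylphenyl on a carbonyl carbon), at a place described in identical terms in both pairs; it is the second time this change appears among these compounds. Compound 4 is therefore expected to show a 2.4-fold lower number from compound 3 to compound 4 (0.37 log units; beyond the scatter), a step of the same kind as a 2.4-fold lower number from compound 1 to compound 2 (0.38 log units; beyond the scatter), resting on that earlier step and on the near-equal values of compound 1 and compound 3. Compound 4 is estimated at 4500 nM, most likely between 2000 nM and 10000 nM.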

Compound 4, half-maximal inhibitory concentration: 17800 nM
Estimate against measurement, compound 4: 4.0-fold (0.60 log units) below; the measured number lies above the stated range.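

In this assay, 3,4-dimethoxyphenyl in place of 3,4-dimethylphenyl on the carbonyl carbon gave a 1.7-fold higher number from compound 3 to compound 4 (0.23 log units; within the scatter), so the improvement seen on the first core did not carry over to the second: the same change on two cores in this assay, a 2.4-fold lower number (0.38 log units; beyond the scatter) from compound 1 to compound 2 and a 1.7-fold higher number (0.23 log units; within the scatter) from compound 3 to compound 4, 4.0-fold (0.60 log units) apart, beyond the scatter of two such steps. The added methoxy also behaved differently depending on the group on the carbonyl carbon, here giving a 4.6-fold higher number from compound 2 to compound 4 (0.66 log units; beyond the scatter): the same change on two cores in this assay, a 1.1-fold higher number (0.06 log units; within the scatter) from compound 1 to compound 3 and a 4.6-fold higher number (0.66 log units; beyond the scatter) from compound 2 to compound 4, 4.0-fold (0.60 log units) apart, beyond the scatter of two such steps. Across these four compounds the two changes therefore do not simply add, but the data do not show why, and one pair per core gives no rule for other cores.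

On these data alone, it remains open how a group such as an amine or a carboxylic acid on the phenyl ring at the carbonyl carbon would behave on either core. As far as these compounds go, it is also open whether this dependence on the core holds in other cell lines.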